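Working notes: hydroxy for methoxy in a cytotoxicity series

This account rests on a few compounds, and the source may have more. Where it says the series, first, only, none or still open, it means among the compounds named here.

Measured so far:
compound 1 `COc1cc(C)cc(-c2nn(CC#N)cc2-c2ccc(-c3cccc(C(C)=O)c3)nc2)c1`: 69%
compound 2 `Cc1cc(O)cc(-c2nn(CC#N)cc2-c2ccnc(-c3ccc(Oc4ccccc4)cc3)c2)c1`: 75%
compound 3 `COc1cc(C)cc(-c2nn(CC#N)cc2-c2ccnc(-c3ccc(N(C)C)cc3)c2)c1`: 14%

In a functional assay on CAKI-1 cells (Homo sapiens) for cytotoxicity, read by sulforhodamine B assay, with a stated time of 48 h, tested at 100 nM (on this read-out higher numbers stand for a weaker effect at the one concentration tested and lower numbers for a stronger effect), compound 3 stands lowest of the three numbers, which on this read-out means the strongest effect of the set. Compound 1 lies beyond the scatter above it, and compound 2 further still, so compound 3 is clearly apart from both.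

Compound 4 `Cc1cc(O)cc(-c2nn(CC#N)cc2-c2ccnc(-c3ccc(N(C)C)cc3)c2)c1` is the next point to place. It differs from compound 3 by hydrogen in place of methyl on an oxygen on an aromatic ring. Among the measured compounds shown here, no pair of measured compounds shows this change on its own: compound 2 carries the hydroxy group, but it also differs from compound 3 elsewhere, so the gap between compound 2 and compound 3 reflects both changes together and cannot be read as the size of this one.

Given only that, a step in this assay of moderate size toward a weaker effect is expected, a number 16 percentage points higher from compound 3 to compound 4 (beyond the scatter), with the possibility that it stays within the scatter kept open. Compound 4 is estimated at 30%, in the range 10% to 65%.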

Compound 4, a percentage reported as activity, at one concentration (the size of the read-out at that concentration, not a potency): 85%
Compound 4: the middle estimate sits 55 percentage points below what was measured; the measured number lies above the stated range.
By their numbers in this assay, from the lowest: compound 3; then compounds 1, 2 and 4 (each within the scatter of the next, the first and the last beyond it).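

Among the compounds shown here, with dimethylamino held in place, hydrogen in place of methyl on an oxygen on an aromatic ring gives in this assay a number 71 percentage points higher from compound 3 to compound 4 (beyond the scatter), the first reading of this change on its own, and methoxy to hydroxy here goes with a large loss of effect at the one concentration tested. With hydroxy held in place, dimethylamino in place of phenoxy gives a number 10 percentage points higher from compound 2 to compound 4 (within the scatter), so this change does not separate the two hydroxy compounds on this read-out. Nothing available explains the large step from methoxy to hydroxy.

On these data alone, the methoxy to hydroxy step is read only with dimethylamino present, so its size with phenoxy or another group stays open. Also open, as far as these compounds go, is whether ethyl or a longer chain on that oxygen would keep the strong effect seen with methyl.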